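The source may hold more compounds than are shown below. What is called first, only, known or untested is meant among the compounds shown, and "the series" means these compounds.

- Compound 1 `N#Cc1ccc(/C=C/S(=O)(=O)Cc2ccc(Nc3ncnc4ccccc34)cc2)cc1`: > 100000 nM, a limit of the assay and not a number
- Compound 2 `O=S(=O)(/C=C/c1ccc(Cl)c(Cl)c1)Cc1ccc(Nc2ncnc3ccccc23)cc1`: 11000 nM
- Compound 3 `O=S(=O)(/C=C/c1ccc(Cl)c(Cl)c1)Cc1ccc(Nc2ncnc3ccc(Br)cc23)cc1`: 27000 nM

In a functional assay on HT-29 cells (Homo sapiens) (a lower number here means a stronger inhibitor of growth, a higher number a weaker inhibitor of growth), only compound 2 and compound 3 give actual numbers. Compound 3 has the higher of the two, making it the weaker growth inhibitor of this pair.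

Compound 4 `O=S(=O)(/C=C/c1ccc(Cl)cc1Cl)Cc1ccc(Nc2ncnc3ccc(Br)cc23)cc1` has the same atoms as compound 3, joined differently: 2,4-dichlorophenyl in place of 3,4-dichlorophenyl on a double-bonded chain carbon bound to a double-bonded chain carbon.

The closest measured precedent is an at least 9.0-fold lower number from compound 1 to compound 2 (0.95 log units; beyond the scatter). It shows that changing this aromatic group can shift the number, but it exchanged one group for a quite different one and did not rearrange the same atoms. The other measured step, a 2.5-fold higher number from compound 2 to compound 3 (0.39 log units; beyond the scatter), added a bromo that compound 3 and compound 4 both carry, so it offers little guidance here. For the measured compounds named here, no measured pair shows the effect of going from 3,4-dichlorophenyl to 2,4-dichlorophenyl, so no direction can be favoured, and a modest move either way remains possible.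

The expected step is a 1.1-fold higher number from compound 3 to compound 4 (0.05 log units; within the scatter). For compound 4, the estimate is 30000 nM, with an expected range of 9000 nM to 100000 nM.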

Compound 4, concentration for 50% growth inhibition: 28000 nM
Compound 4: the middle estimate sits 1.1-fold (0.03 log units) above what was measured; the range from low to high includes it.
By their numbers in this assay, from the lowest: compound 2; then compounds 3 and 4 (each within the scatter of the next). At a limit, above all of these: compound 1.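

In this assay, rearranging the same atoms from 3,4-dichlorophenyl to 2,4-dichlorophenyl gives a 1.0-fold higher number from compound 3 to compound 4 (0.02 log units; within the scatter). Compound 3 and compound 4 therefore cannot be told apart in this assay, so this particular shift of one chlorine, on a double-bonded chain carbon bound to a double-bonded chain carbon, shows no measurable effect, whereas the earlier exchange of 4-cyanophenyl for 3,4-dichlorophenyl replaced the whole group. No measurement shown here bears on why these two compounds match.

It remains open whether the same match would hold in a compound without the bromo, as compound 2 has no 2,4-dichlorophenyl partner among the compounds shown. Also open, on these data alone, is how this aromatic ring would behave if it carried an amine or a carboxylic acid instead of chlorine.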